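Aryl swap on the triazole nitrogen of compound 3

The source may report more compounds than this note shows. Statements on the series, on what has been measured and on what is new or still open speak of the compounds shown alone.

Measured in a functional assay on PC-3 cells (Homo sapiens) for inhibition, read by MTT assay, with a stated time of 72 h; a higher number here means a weaker inhibitor, a lower number a stronger inhibitor:
Compound 1, `CC(C)n1ncc2c(C(=O)Nc3cccnc3)cccc21`, gives > 40000 nM, which is a limit of the assay and not a number.
Compound 2, `CC(C)n1ncc2c(C(=O)NC3CCCC3)cccc21`, gives 19400 nM.
Compound 3, `Cc1ccc(-n2cc(CNC(=O)c3cccc4c3cnn4C(C)C)nn2)cc1C`, gives 23400 nM.

Compound 3 stands level with compound 2, the two numbers lying within the usual scatter of each other. Compound 1 contributes only a limit, (the limit of > 40000 nM in this assay, at which 1 of the 3 values shown sits), so compound 3 cannot be ranked against it.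

Compound 4, `CC(C)n1ncc2c(C(=O)NCc3cn(-c4ccc(F)cc4)nn3)cccc21`, differs from compound 3 in one place: 4-fluorophenyl in place of 3,4-dimethylphenyl on an aromatic nitrogen. Going by the values given here, the only measured step, an at least 2.0-fold lower number from compound 1 to compound 2 (0.31 log units; beyond the scatter), concerns the group on the amide nitrogen rather than the group on the triazole nitrogen, so no measured step touches the change in question. With nothing pointing either way, compound 4 is expected to remain close to compound 3, and a 1.0-fold higher number from compound 3 to compound 4 (0.01 log units; within the scatter) is expected to fall within the scatter. The estimate for compound 4 in this assay is 24000 nM, with a range from 9000 nM to 60000 nM.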

Compound 4, half-maximal inhibitory concentration: > 40000 nM
Compound 4: only a limit was reported; the forecaster's own chance of this, stated with the estimate: 30%; at least 1.6-fold (0.22 log units) between middle value and limit.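

In this assay compound 4 gives > 40000 nM, which is a limit of the assay and not a number. Going by these compounds alone, this is the first reading of a change on this aromatic nitrogen of the five-membered ring, and 4-fluorophenyl in place of 3,4-dimethylphenyl gives an at least 1.7-fold higher number from compound 3 to compound 4 (0.23 log units; that floor lies within the scatter), so the direction is upward but its printed floor cannot be told apart from scatter. Within the data shown here, the true size of the step stays unknown, and the reading shows only that compound 4 joins the values at the top of the range: the limit of > 40000 nM in this assay, at which 2 of the 4 values shown sit.

Going by these compounds, it remains open whether any group on this nitrogen can bring the number clearly below that of compound 3. On these data alone, it is also open whether an amine or a carboxylic acid on the phenyl ring, or a longer alkyl chain in its place, would move the number at all.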